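Swapping a trifluoromethoxyphenyl for a dimethylphenyl

A few compounds are considered here, and "the series" means these few. Any claim that something is new, unique, unknown or untested is made for them only; others in the source may bear on it.

Of the compounds shown here, three built on a shared core have been tested in a functional assay on A549 cells (Homo sapiens) for cytotoxicity, read by MTT assay, with a stated time of 72 h; on this read-out lower numbers stand for stronger inhibition and higher numbers for weaker inhibition. Compound 2 `COc1cc2c(Oc3ccc(NC(=O)c4cn(-c5ccccc5OC)cn4)cc3F)ccnc2cc1OCCCN1CCCCC1` gives 120 nM, compound 3 `COc1cc2c(Oc3ccc(NC(=O)c4cn(-c5ccccc5OC(F)(F)F)cn4)cc3F)ccnc2cc1OCCCN1CCCCC1` gives 270 nM, and compound 1 `COc1cc2c(Oc3ccc(NC(=O)c4cn(-c5cc(C)ccc5C)cn4)cc3F)ccnc2cc1OCCCN1CCN(C)CC1` gives 350 nM. Compound 3 therefore sits at the second highest of the three numbers, close to compound 1 and further from compound 2. Going by the values given here, the only single-point step among them is a 2.3-fold higher number from compound 2 to compound 3 (0.35 log units; beyond the scatter), a modest change.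

Compound 4 `COc1cc2c(Oc3ccc(NC(=O)c4cn(-c5cc(C)ccc5C)cn4)cc3F)ccnc2cc1OCCCN1CCCCC1` arises from compound 3 by the change (2,5-dimethylphenyl in place of 2-(trifluoromethoxy)phenyl on an aromatic nitrogen). Among the compounds with values here, no measured step covers this exact swap. Compound 1 already carries the 2,5-dimethylphenyl group, with a different chain end, and its value of 350 nM lies within the scatter of compound 3. The step from compound 3 to compound 4 is therefore expected to be small, a 1.0-fold lower number from compound 3 to compound 4 (0.02 log units; within the scatter), with no clear direction. Compound 4 is estimated at 260 nM, in a range from 100 nM to 650 nM.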

Compound 4, half-maximal inhibitory concentration: 510 nM
Compound 4: the middle estimate sits 2.0-fold (0.29 log units) below what was measured; the measured number falls inside the stated range.
By their numbers in this assay, from the lowest: compound 2; then compounds 3, 1 and 4 (each within the scatter of the next).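

In this assay the 2,5-dimethylphenyl on the aromatic nitrogen can now be set against two oxygen-bearing groups at this position: a 4.3-fold higher number from compound 2 to compound 4 (0.63 log units; beyond the scatter) separates it from 2-methoxyphenyl, while a 1.9-fold higher number from compound 3 to compound 4 (0.28 log units; within the scatter) does not separate it from 2-(trifluoromethoxy)phenyl. Among the compounds with the piperidin-1-yl chain end, the clear gaps therefore all involve compound 2, which carries the 2-methoxyphenyl group. At the chain end itself, a 1.5-fold higher number from compound 1 to compound 4 (0.16 log units; within the scatter) means that piperidin-1-yl and 4-methylpiperazin-1-yl cannot be told apart on this core.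

Nothing measured here accounts for these differences. Still open, going by these compounds, is how an unsubstituted phenyl or a 2-chlorophenyl would compare on that nitrogen, and how a morpholine would compare at the chain end.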